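The compounds below may be only part of what the source reports. "The series", "measured", "known", "first", "only" and "open" are said of these compounds alone.

Compound 1, `Cc1ccc(NC(=S)N/N=C2\C(=O)Nc3ccc(Br)cc32)cc1`: 6800 nM
Compound 2, `Cc1ccc(NC(=S)N/N=C2\C(=O)Nc3ccc(F)cc32)cc1`: 4800 nM

Both numbers come from a functional assay on CCRF-CEM cells (Homo sapiens), with a stated time of 72 h; on this read-out higher numbers stand for weaker inhibition and lower numbers for stronger inhibition. Among the measured compounds shown here, compound 1 has the highest of the two numbers; its nearest neighbour is compound 2, and the only measured step, a 1.4-fold lower number from compound 1 to compound 2 (0.15 log units; within the scatter), lies within the usual scatter, so the two values show no real difference between them. Compound 3, `Cc1ccc(NC(=S)N/N=C2\C(=O)N(Cc3ccc(Cl)cc3)c3ccc(Br)cc32)cc1`, differs from compound 1 by 4-chlorobenzyl in place of hydrogen on an amide-type nitrogen in a ring. For the measured compounds named here, no measured step touches that amide-type nitrogen in a ring: the one step known concerns a halogen on an aromatic carbon, and it was small. Nothing in these two numbers points in either direction for a group added there, so the expectation rests on compound 1 alone and stays broad. The expected step is a 1.4-fold lower number from compound 1 to compound 3 (0.13 log units; within the scatter), that is, no change beyond the scatter, with a wide range allowed. Compound 3 is therefore estimated at 5000 nM in this assay, between 1000 nM and 25000 nM.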

Compound 3, half-maximal inhibitory concentration: >= 500000 nM
Compound 3: only a limit was reported (the forecaster's own chance of this, stated with the estimate: 5%); middle value at least 100-fold (2.00 log units) from the limit.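

Replacing the amide hydrogen with 4-chlorobenzyl on the amide-type nitrogen in a ring has a large effect in this assay, giving an at least 73-fold higher number from compound 1 to compound 3 (1.86 log units; beyond the scatter). The reading for compound 3 is a limit and not a number: the limit of >= 500000 nM in this assay, at which 1 of the 3 values shown sits. The earlier halogen step said nothing about this nitrogen, and this result shows that, on the core of compound 1, the position is sensitive to this change, with inhibition in this assay largely lost.

As far as these compounds go, it remains open whether a methyl group, a plain benzyl without the chlorine, or a chain ending in an amine or a carboxylic acid on that nitrogen would bring the same loss. From the compounds shown here alone, it is also open whether 4-chlorobenzyl would give a similar step on compound 2.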